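The source may hold more compounds than are shown below. What is called first, only, known or untested is meant among the compounds shown, and "the series" means these compounds.

Measured compounds:
- compound 1 `CC1=C(C(=O)OC(C)(C)C)C(c2ccoc2)NC(=O)N1`: 2%
- compound 2 `COC(=O)C1=C(C)N(C)C(=O)NC1c1ccoc1`: 7%
- compound 3 `CC1=C(C(=O)OCC(C)C)C(c2ccoc2)NC(=O)N1C`: 16%

All three were run in an assay on membranes from HeLa cells for displacement of a labelled ligand from adenosine receptor A3 (Homo sapiens), read by scintillation counting, with a stated time of 180 min, tested at 1 uM; a lower number here means less inhibition, a higher number more inhibition at the concentration tested (going by the name of the read-out). Of the three, compound 3 carries the largest number in this assay; the gap to compound 2 is within the usual scatter, so those two cannot be separated, while compound 1 lies beyond it.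

Compound 4 `CC1=C(C(=O)OC(C)(C)C)C(c2ccoc2)NC(=O)N1C` has not yet been measured. It differs from compound 3 by tert-butyl in place of isobutyl on an oxygen next to a carbonyl group.

For the measured compounds named here, only one measured step touches the ester chain: a number 9 percentage points higher from compound 2 to compound 3 (within the scatter). That change grew the chain but did not move the number beyond the scatter. Nothing measured speaks to exchanging one four-carbon chain for another of the same size on the same oxygen. Compound 1 also carries a tert-butyl on that oxygen, but it differs from compound 4 in a second place as well, so its value in this assay can only be noted, not used as a step.

Going by the values given here, with the one relevant step flat, no move beyond the scatter is expected from compound 3 to compound 4: the estimated step is a number 4 percentage points lower from compound 3 to compound 4 (within the scatter). Compound 4 is therefore expected to give about 12% in this assay, with a range from 2% to 25%.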

Compound 4, a percentage reported as inhibition, at one concentration (the size of the read-out at that concentration, not a potency): 12%
Estimate against measurement, compound 4: no gap at the digits printed, within the range that was stated.
By their numbers in this assay, from the lowest: compounds 1, 2, 4 and 3 (each within the scatter of the next, the first and the last beyond it).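

Within this assay, the exchange of isobutyl for tert-butyl on an oxygen next to a carbonyl group gives a number 4 percentage points lower from compound 3 to compound 4 (within the scatter) and is the first direct comparison of two chains with the same heavy-atom count at this position. Methyl on the same oxygen can now be compared with tert-butyl as well, giving a number 5 percentage points higher from compound 2 to compound 4 (within the scatter) and so, together with a number 9 percentage points higher from compound 2 to compound 3 (within the scatter), leaving methyl, isobutyl and tert-butyl unseparated here when the ring nitrogen carries methyl. The ring position also gets its first readable step, with methyl in place of hydrogen on an amide-type nitrogen in a ring giving a number 10 percentage points higher from compound 1 to compound 4 (within the scatter) and thus no change beyond the scatter for a compound with tert-butyl on the oxygen.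

No supporting data bear on what lies behind these flat steps. Still open, as far as these compounds go, is whether a longer chain, a chain ending in an amine or a carboxylic acid on that oxygen would move the read-out beyond the scatter, and whether ethyl on the ring nitrogen would do so.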